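Swapping Bromo for Methyl on a Shared Core

The compounds below may be only part of what the source reports. "The series", "measured", "known", "first", "only" and "open" are said of these compounds alone.

Compound 1, `CC(=O)Oc1ccc(/C=C/C(=O)OCCSc2nc(-c3ccc(S(N)(=O)=O)cc3)n(-c3ccc(F)cc3)n2)cc1OC(C)=O`, gives 12000 nM
Compound 2, `CC(=O)Oc1ccc(/C=C/C(=O)NCCCSc2nc(-c3ccc(S(C)(=O)=O)cc3)n(-c3ccc(F)cc3)n2)cc1OC(C)=O`, gives 21800 nM
Compound 3, `COc1cc(/C=C/C(=O)OCCSc2nc(-c3ccc(S(C)(=O)=O)cc3)n(-c3ccc(Br)cc3)n2)ccc1OC(C)=O`, gives 11100 nM

These three values come from a functional assay on A549 cells (Homo sapiens) for antiproliferative activity, read by MTT assay, with a stated time of 72 h; on this read-out higher numbers stand for weaker inhibition and lower numbers for stronger inhibition. Compound 3 has the lowest of the three numbers, but its gap to compound 1 and its gap to compound 2 both fall within the usual scatter of repeated measurements, so the three compounds cannot be told apart on these data alone. Going by the values given here, no pair of measured compounds differs in just one place, so there is no measured step to lean on.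

Compound 4, `COc1cc(/C=C/C(=O)OCCSc2nc(-c3ccc(S(C)(=O)=O)cc3)n(-c3ccc(C)cc3)n2)ccc1OC(C)=O`, is the compound not yet measured. It differs from compound 3 in one place: methyl in place of bromo on an aromatic carbon. Among the compounds with values here, nothing among the measured compounds shows what this particular exchange does, and both groups are small, neutral, and carry neither hydrogen-bond donors nor acceptors. The plainest expectation is therefore a step from compound 3 to compound 4 of a 1.2-fold higher number from compound 3 to compound 4 (0.07 log units; within the scatter), that is, no change beyond the scatter, with the estimate leaning very slightly toward a higher number. Compound 4 is expected to give 13000 nM in this assay, with a range from 6000 nM to 30000 nM.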

Compound 4, half-maximal inhibitory concentration: 15000 nM
The estimate for compound 4 lay 1.2-fold (0.06 log units) below the measured number; measured number inside the range.
By their numbers in this assay, from the lowest: compounds 3, 1, 4 and 2 (each within the scatter of the next).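

In this assay, going by these compounds alone, the exchange of 4-bromophenyl for 4-methylphenyl gives a 1.4-fold higher number from compound 3 to compound 4 (0.13 log units; within the scatter), and this is the first comparison where only one place differs. At this position, para to a large group on the shared core, bromo and methyl therefore cannot be told apart on this read-out, so a change of this kind leaves the antiproliferative result within ordinary measurement noise. No accompanying measurement bears on why the two groups behave alike here, and the step alone cannot supply an explanation.

This single pair cannot show whether the same exchange would behave alike on another background, such as the cores of compound 1 or compound 2, which carry a fluoro group at the corresponding ring and differ elsewhere as well. It also leaves open whether a group of a different kind at this position, such as an amine, a carboxylic acid or a longer chain, would move the number beyond the scatter, or whether this position simply has little influence on the result.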